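Nitro to nitrile on the hydrazone aryl of compound 1

The source may report more compounds than this note shows. Statements on the series, on what has been measured and on what is new or still open speak of the compounds shown alone.

Going by the values given here, compound 1, `CC(=O)/C(=N\Nc1ccccc1[N+](=O)[O-])N(C)c1cccc(Cl)c1`, is the one member of this small set with a plain number in an assay on isolated protein for binding affinity to corticotropin-releasing factor receptor 1 (Homo sapiens); on this read-out lower numbers stand for stronger inhibition and higher numbers for weaker inhibition: compound 1 gives 8600 nM. Compound 2, `CC(=O)/C(=N\Nc1ccccc1Cl)Nc1cccc(Cl)c1`, has two entries in this assay, each reading 417 nM; 417 nM (2 entries). Compound 3, `CC(=O)/C(=N\Nc1ccccc1Cl)Sc1cccc(Cl)c1`, reaches only the limit of this assay, > 10000 nM, which is a limit and not a number (the limit of > 10000 nM in this assay, at which 1 of the 3 values shown sits). Among the compounds with values here, no two of these three differ in a single place, so no measured step is available, and the scatter of this assay has to serve as the yardstick for what follows.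

Compound 4, `CC(=O)/C(=N\Nc1ccccc1C#N)N(C)c1cccc(Cl)c1`, differs from compound 1 by cyano in place of nitro on an aromatic carbon, in short cyano in place of nitro on an aromatic carbon. Within the data shown here, with no measured step to lean on, a step of about the size of the scatter is expected from compound 1 to compound 4, leaning toward stronger binding, a 1.7-fold lower number from compound 1 to compound 4 (0.24 log units; within the scatter). For compound 4 the estimate in this assay is 5000 nM, expected to fall between 1500 nM and 15000 nM.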

Compound 4, inhibition constant: > 10000 nM
Compound 4: a limit, no number; the forecaster's own chance of this, stated with the estimate: 25%; at least 2.0-fold (0.30 log units) between middle value and limit.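

In this assay compound 4 gives only a limit and not a number: the limit of > 10000 nM in this assay, at which 2 of the 4 values shown sit.

Going by these compounds alone, this provides the first measured single-place step in the set, an at least 1.1-fold higher number from compound 1 to compound 4 (0.06 log units; that floor lies within the scatter), so cyano in place of nitro on this aromatic carbon, ortho to a large group, shows no gain in binding. Since the floor of that step lies within the scatter, the data do not establish a real weakening either, and the true size of the step cannot be read.

The compounds shown leave open whether a methoxy group, an amine or a carboxylic acid on this same aromatic carbon would give a plain number in this assay. They also leave open how far the true value of compound 4 lies from its limit.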